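A few compounds are considered here, and "the series" means these few. Any claim that something is new, unique, unknown or untested is made for them only; others in the source may bear on it.

Compounds measured in an assay on isolated protein for inhibition of Maltase-glucoamylase (Homo sapiens), with a stated time of 15 min; a higher number here means a weaker inhibitor, a lower number a stronger inhibitor:
compound 1 `O=C(N/N=C/c1cccnc1)c1ccc(-c2nc3ccccc3s2)cc1` — "not active" (no number reported)
compound 2 `O=C(N/N=C/c1cccc(O)c1O)c1ccc(-c2nc3ccccc3s2)cc1` — 11200 nM
compound 3 `O=C(N/N=C/c1ccc(O)c(O)c1)c1ccc(-c2nc3ccccc3s2)cc1` — 15100 nM

Compound 3 gives the highest of the two numbers, with compound 2 nearest a 1.3-fold higher number from compound 2 to compound 3 (0.13 log units; within the scatter); compound 1 reported no number at all. Compound 4 `O=C(N/N=C/c1ccncc1)c1ccc(-c2nc3ccccc3s2)cc1` carries pyridin-4-yl in place of 3,4-dihydroxyphenyl on a carbon with a double bond to nitrogen. Among the compounds with values here, no measured step covers this change directly. Within the data shown here, only compound 1 bears on it, a pyridin-3-yl analogue without any hydroxyl that was found not active, so the two dihydroxyphenyl compounds are the sole ones with reported numbers. Compound 4 is therefore expected to move toward weaker inhibition a 3.3-fold higher number from compound 3 to compound 4 (0.52 log units; beyond the scatter), with a real chance that this assay reports only a limit. The estimate for compound 4 is 50000 nM, within 15000 nM to 200000 nM.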

Compound 4, half-maximal inhibitory concentration: "not active" (no number reported)
Compound 4: no number reported; the estimate stays without a comparison.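

In this assay compound 4 gives "not active" (no number reported) and so no step from compound 3 can be read, and nothing shown accounts for this result. The compounds shown leave open how far compound 1 and compound 4 fall from compound 2 and compound 3 in strength.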